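Cytotoxicity notes: furanylmethyl-amine series, aryl substituent variation

A few compounds are considered here, and "the series" means these few. Any claim that something is new, unique, unknown or untested is made for them only; others in the source may bear on it.

Measured so far in an ADME assay on HepG2 cells (Homo sapiens) for cytotoxicity, read by luminescence, CellTiter-Glo and ATP content, with a stated time of 72 h; on this read-out lower numbers stand for an effect already at smaller amounts and higher numbers for an effect only at larger amounts of compound:
- compound 1 `Fc1ccc(-c2ccc3c(NCCCNCc4ccco4)ccnc3c2)cc1`: 7760 nM
- compound 2 `CC(C)CCc1ccc2c(NCCCNCc3ccco3)ccnc2c1`: 11200 nM
- compound 3 `c1ccc(CCc2ccc3c(NCCCNCc4ccco4)ccnc3c2)cc1`: 16000 nM

Compound 3 stands at the highest of the three numbers in this assay. Its nearest neighbour is compound 2, a 1.4-fold higher number from compound 2 to compound 3 (0.15 log units; within the scatter); its furthest is compound 1, a 2.1-fold higher number from compound 1 to compound 3 (0.31 log units; beyond the scatter). Among the measured compounds shown here, the whole set spans a narrow band, and the one step between compound 1 and compound 2, a 1.4-fold higher number from compound 1 to compound 2 (0.16 log units; within the scatter), stays inside the scatter.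

Compound 4 `COc1cccc(Oc2ccc3c(NCCCNCc4ccco4)ccnc3c2)c1` differs from compound 3 in one place: 3-methoxyphenoxy in place of phenethyl on an aromatic carbon. For the measured compounds named here, the steps that bear on it are those that exchanged the group on this same aromatic carbon, a 2.1-fold higher number from compound 1 to compound 3 (0.31 log units; beyond the scatter) and a 1.4-fold higher number from compound 2 to compound 3 (0.15 log units; within the scatter). Both were small, and none of them introduced an ether-linked aryl group or an added oxygen acceptor, so no direction can be read from them. In this assay the estimate for compound 4 is therefore 12000 nM, with a range from 5000 nM to 30000 nM, the expected step being a 1.3-fold lower number from compound 3 to compound 4 (0.12 log units; within the scatter), not beyond the scatter.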

Compound 4, half-maximal effective concentration: 15500 nM
Beside the measured number, compound 4's estimate is 1.3-fold (0.11 log units) below it; measured number inside the range.
By their numbers in this assay, from the lowest: compounds 1, 2, 4 and 3 (each within the scatter of the next, the first and the last beyond it).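

In this assay, 3-methoxyphenoxy, an ether-linked aryl group with 2 hydrogen-bond acceptors, takes the place of phenethyl, which has none, and the number holds (a 1.0-fold lower number from compound 3 to compound 4 (0.01 log units; within the scatter)). Against isopentyl (a 1.4-fold higher number from compound 2 to compound 4 (0.14 log units; within the scatter)) and 4-fluorophenyl (a 2.0-fold higher number from compound 1 to compound 4 (0.30 log units; within the scatter)), the new group also stays within the scatter, so this aromatic carbon now carries an ether-linked aryl group as well as directly attached aryl and saturated-chain groups with little spread in the numbers. The only step among these four compounds beyond the scatter remains the one that goes against this picture (a 2.1-fold higher number from compound 1 to compound 3 (0.31 log units; beyond the scatter)), and it is modest.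

Still open, from the compounds shown here alone, is whether an amine or a carboxylic acid on this aromatic carbon would give a step beyond the scatter. Nothing at hand explains why these four numbers lie so close together.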